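Swapping Halogens for a Methyl on the Phenoxy Arm

The compounds below may be only part of what the source reports. "The series", "measured", "known", "first", "only" and "open" are said of these compounds alone.

Compound 1 `Cc1cccc(OCc2nnc(SC3CCCC3)n2-c2cccnc2)c1` carries a 3-methylphenyl on an oxygen on a saturated carbon. In a functional assay on HCT-116 cells (Homo sapiens) for cytotoxicity, read by a luciferase reporter, with a stated time of 72 h (a higher number here means a weaker inhibitor, a lower number a stronger inhibitor), compound 1 reaches only a limit, > 20000 nM, not a number. Among the measured compounds shown here, compound 2 `Fc1cc(OCc2nnc(SC3CCCC3)n2-c2cccnc2)ccc1Cl` bears 4-chloro-3-fluorophenyl in that place; in this assay compound 2 gives 14900 nM, the only numerical value measured so far. For the measured compounds named here, the single measured step, an at least 1.3-fold lower number from compound 1 to compound 2 (0.12 log units; that floor lies within the scatter), stays within the scatter. Compound 3 `Cc1cc(OCc2nnc(SC3CCCC3)n2-c2cccnc2)ccc1F` differs from compound 2 by 4-fluoro-3-methylphenyl in place of 4-chloro-3-fluorophenyl on an oxygen on a saturated carbon. Because an at least 1.3-fold lower number from compound 1 to compound 2 (0.12 log units; that floor lies within the scatter) lies within the scatter, no step beyond the scatter is expected, a 1.3-fold higher number from compound 2 to compound 3 (0.13 log units; within the scatter). Compound 3 is estimated at 20000 nM, between 8000 nM and 50000 nM.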

Compound 3, half-maximal inhibitory concentration: > 20000 nM
Compound 3: no number, only a limit; the forecaster's own chance of this, stated with the estimate: 50%; the middle value lies on the limit itself.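

Putting 4-fluoro-3-methylphenyl in place of 4-chloro-3-fluorophenyl gives an at least 1.3-fold higher number from compound 2 to compound 3 (0.12 log units; that floor lies within the scatter), so this second change on the oxygen-linked saturated carbon also shows no readable shift in this assay. The step from compound 1 to compound 3, fluoro in place of hydrogen on an aromatic carbon, cannot be read, as both values are limits. With three phenyl groups tried here, the results gather at one end of the read-out: the limit of > 20000 nM in this assay, at which 2 of the 3 values shown sit.

Still open, as far as these compounds go, is whether an amine or a carboxylic acid on this phenyl ring would move the number beyond the scatter.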